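A few compounds are considered here, and "the series" means these few. Any claim that something is new, unique, unknown or untested is made for them only; others in the source may bear on it.

Working notes on the series. Of the compounds shown here, two sharing the same core have been measured in a functional assay on MDA-MB-231 cells (Homo sapiens) for antiproliferative activity, read by MTT assay, with a stated time of 48 h; on this read-out higher numbers stand for weaker inhibition and lower numbers for stronger inhibition. Compound 1 `CC(=O)Oc1ccccc1C(=O)OCC[Se]C#N` gives 23800 nM in this assay, and compound 2 `CC(=O)Oc1ccccc1C(=O)[Se]CC[Se]C(=O)c1ccccc1OC(C)=O` gives 11000 nM. Compound 1 thus stands at the highest of the two numbers, and the gap down to compound 2 lies beyond the usual scatter; as the two structures differ in more than one place, nothing more is read from that pair.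

The next compound to be measured is compound 3 `CC(=O)Oc1ccccc1C(=O)NCCSC#N`. It differs from compound 1 in one place: a group of 6 heavy atoms (3 carbon, 2 nitrogen, 1 sulfur; no ring) in place of a group of 6 heavy atoms (3 carbon, 1 nitrogen, 1 oxygen, 1 selenium; no ring), on a carbonyl carbon. For the measured compounds named here, no measured pair isolates a change of this kind, so the direction of the step is uncertain and the expectation rests on compound 1 alone. Going by the values given here, compound 3 is expected to show a modest step toward a higher number, a 1.7-fold higher number from compound 1 to compound 3 (0.23 log units; within the scatter), because compound 1 already gives 23800 nM and the series so far sits in the weak range of this assay. In this assay compound 3 is therefore estimated at 40000 nM, with a range from 15000 nM to 120000 nM.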

Compound 3, half-maximal inhibitory concentration: > 50000 nM
Compound 3 gave a limit, no number; the forecaster's own chance of this, stated with the estimate: 25%; at least 1.2-fold (0.09 log units) between middle value and limit.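

In this assay compound 3 gives a limit and not a number: the limit of > 50000 nM in this assay, at which 1 of the 3 values shown sits. Even so, the change on the carbonyl carbon whose other neighbour is an aromatic carbon yields the first readable step in the series, an at least 2.1-fold higher number from compound 1 to compound 3 (0.32 log units; beyond the scatter), so the group at this place can move the read-out toward weaker inhibition by more than the usual scatter. The step gives only a lower bound on its size, and it bundles several exchanges, since the (2-(cyanosulfanyl)ethyl)amino group brings sulfur in place of selenium, nitrogen in place of the oxygen link and one hydrogen-bond donor where the leaving group has none.

The compounds shown do not separate these exchanges, so it remains open whether the step follows the loss of selenium or the change of link, a question that a (2-(cyanoselanyl)ethyl)amino group on the same carbonyl carbon would bear on directly. Also open, going by these compounds, is how the read-out responds to chain length at this place, for example with a longer chain between the nitrogen and the thiocyanate sulfur.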